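A few compounds are considered here, and "the series" means these few. Any claim that something is new, unique, unknown or untested is made for them only; others in the source may bear on it.

Compound 3 `COC(=O)/C=C/c1ccc(CN(C(=O)C2CCCCC2)c2cccc(/C=C/C(=O)OC)c2)cc1` is the only one of the three measured compounds that reaches no number in an assay on isolated protein with Bile acid receptor (Homo sapiens) as the target; on this read-out higher numbers stand for an effect only at larger amounts of compound and lower numbers for an effect already at smaller amounts: its value, > 1000 nM, is a limit of the assay. Compound 1 `COC(=O)/C=C/c1cccc(N(Cc2ccc(-c3ccc(OC(F)(F)F)cc3)cc2)C(=O)C(C)C)c1` gives 219 nM in this assay, and compound 2 `COC(=O)/C=C/c1cccc(N(Cc2ccc(-c3ccc(C(C)(C)C)cc3)cc2)C(=O)C2CCCCC2)c1` gives 132 nM. Compound 4 `COC(=O)/C=C/c1cccc(N(Cc2ccc(-c3ccc(OC(F)(F)F)cc3)cc2)C(=O)C2CCCCC2)c1` differs from compound 3 by 4-(trifluoromethoxy)phenyl in place of 2-(methoxycarbonyl)ethenyl on an aromatic carbon. Among the compounds with values here, the one measured step that bears on this is the reverse kind of change: an at least 7.5-fold higher number from compound 2 to compound 3 (0.87 log units; beyond the scatter). The change leading to compound 4 undoes that loss with a related aryl group, so a sizeable fall in this assay is expected, an at least 6.6-fold lower number from compound 3 to compound 4 (0.82 log units; beyond the scatter), and compound 4 is estimated at 150 nM, within a range of 60 nM to 400 nM.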

Compound 4, half-maximal effective concentration: 264 nM
Compound 4: the middle estimate sits 1.8-fold (0.25 log units) below what was measured, within the range that was stated.
By their numbers in this assay, from the lowest: compounds 2, 1 and 4 (each within the scatter of the next). At a limit, above all of these: compound 3.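

Within the data shown here, putting 4-(trifluoromethoxy)phenyl in place of 2-(methoxycarbonyl)ethenyl gives an at least 3.7-fold lower number from compound 3 to compound 4 (0.57 log units; beyond the scatter) and shows that 4-(tert-butyl)phenyl is not the only aryl group at this place that gives a measured number. Trifluoromethoxy in place of tert-butyl gives a 2.0-fold higher number from compound 2 to compound 4 (0.30 log units; within the scatter) and cyclohexyl in place of isopropyl gives a 1.2-fold higher number from compound 1 to compound 4 (0.08 log units; within the scatter) so neither swap moves the number beyond the scatter. The first step is only a minimum because compound 3 stands at a limit: the limit of > 1000 nM in this assay, at which 1 of the 4 values shown sits.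

Going by these compounds, what an unsubstituted phenyl, or a phenyl carrying an amine or a carboxylic acid, would give at this place stays open.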